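Pyridinyl for fluorophenyl: compound 2 to compound 3

The source may hold more compounds than are shown below. What is called first, only, known or untested is meant among the compounds shown, and "the series" means these compounds.

Of the compounds shown here, two sharing one core have so far been tested in an assay on isolated protein for inhibition of stearoyl-CoA desaturase 5 (Homo sapiens); a lower number here means a stronger inhibitor, a higher number a weaker inhibitor. Compound 1 `NS(=O)(=O)c1ccc2nc(-c3ccc(-c4ccccc4F)cc3)[nH]c2c1` and compound 2 `CS(=O)(=O)c1ccc2nc(-c3ccc(-c4cccc(F)c4)cc3)[nH]c2c1` differ only in where the fluorine sits on the outer ring and in the substituent on the sulfonyl group. In this assay compound 1 gives > 20000 nM, which is a limit of the assay rather than a number. In this assay compound 2 gives > 20000 nM, likewise a limit and not a number. Compound 2 therefore stands at the limit of > 20000 nM in this assay, at which 2 of the 2 values shown sit, and the numbers shown do not separate it from compound 1.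

Compound 3 `CS(=O)(=O)c1ccc2nc(-c3ccc(-c4ccccn4)cc3)[nH]c2c1` has not yet been measured. It arises from compound 2 by pyridin-2-yl in place of 3-fluorophenyl on an aromatic carbon. No measured step of this kind exists among the compounds shown, so the expectation rests on compound 2 alone. The step that the limit leaves unreadable from compound 2 to compound 3 is expected to be none beyond the scatter. Compound 3 is estimated at 30000 nM, with a range from 8000 nM to 120000 nM, and is expected most probably to be reported again only as a limit.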

Compound 3, half-maximal inhibitory concentration: > 20000 nM
Compound 3 ended at the assay's limit; the forecaster's own chance of this, stated with the estimate: 80%; the middle value does not contradict the limit.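

In this assay compound 3 gives > 20000 nM, again a limit of the assay and not a number. For the compounds shown here, no step from compound 2 to compound 3 can therefore be read, and all the compounds remain at the same limit: the limit of > 20000 nM in this assay, at which 3 of the 3 values shown sit. The compounds shown leave open whether any compound on this shared core gives a measurable value in this assay.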